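Chloro addition on the benzyl ring in a second core

The compounds below may be only part of what the source reports. "The series", "measured", "known", "first", "only" and "open" are said of these compounds alone.

Measured compounds:
Compound 1 `Cc1ccc(-c2nn(-c3ccccc3)cc2C(=O)NOCc2ccccc2Cl)cc1`: 380 nM
Compound 2 `Cc1ccc(-c2nn(-c3ccccc3)cc2C(=O)NOCc2ccc(Cl)cc2Cl)cc1`: 1080 nM
Compound 3 `O=C(NOCc1ccccc1Cl)c1cn(-c2ccccc2)nc1-c1ccc(F)cc1`: 8330 nM

In a functional assay on A549 cells (Homo sapiens) for antiproliferative activity, read by MTT assay, with a stated time of 48 h, in the presence of a further agent that is not named here (on this read-out lower numbers stand for stronger inhibition of growth and higher numbers for weaker inhibition of growth), compound 1 gives 380 nM. Compound 2 carries the change chloro in place of hydrogen on an aromatic carbon and gives 1080 nM, a step of a 2.8-fold higher number from compound 1 to compound 2 (0.45 log units; beyond the scatter). Compound 3 differs from compound 1 in its core by fluoro in place of methyl on an aromatic carbon; in this assay compound 3 gives 8330 nM, which is a 22-fold higher number from compound 1 to compound 3 (1.34 log units; beyond the scatter), and it stands as the highest number of the three measured.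

Compound 4 `O=C(NOCc1ccc(Cl)cc1Cl)c1cn(-c2ccccc2)nc1-c1ccc(F)cc1` is not yet measured. Among the measured compounds shown here, it differs from compound 3 by chloro in place of hydrogen on an aromatic carbon, and this is the same change as the one from compound 1 to compound 2, at the same place in the same words. Because a 2.8-fold higher number from compound 1 to compound 2 (0.45 log units; beyond the scatter) is the only example of this change shown, the step from compound 3 to compound 4 is expected to resemble it, at about a 2.6-fold higher number from compound 3 to compound 4 (0.42 log units; beyond the scatter). This rests on one pair only, and the value of compound 3 is already high, so the number may also come out as a limit. For compound 4 the estimate is 22000 nM, expected between 8000 nM and 60000 nM.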

Compound 4, concentration for 50% growth inhibition: 14000 nM
For compound 4 the middle estimate is 1.6-fold (0.20 log units) above the measured one, within the range that was stated.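

In this assay, the change from 2-chlorobenzyl to 2,4-dichlorobenzyl on the core of compound 3 reads as a 1.7-fold higher number from compound 3 to compound 4 (0.23 log units; within the scatter), and this step does not differ from the one seen on the core of compound 1: the same change on two cores in this assay, a 2.8-fold higher number (0.45 log units; beyond the scatter) from compound 1 to compound 2 and a 1.7-fold higher number (0.23 log units; within the scatter) from compound 3 to compound 4, 1.7-fold (0.23 log units) apart, within the scatter of two such steps The exchange of fluoro for methyl, read a second time with the 2,4-dichlorobenzyl group in place, gives a 13-fold higher number from compound 2 to compound 4 (1.11 log units; beyond the scatter), and the two readings of that exchange also agree: the same change on two cores in this assay, a 22-fold higher number (1.34 log units; beyond the scatter) from compound 1 to compound 3 and a 13-fold higher number (1.11 log units; beyond the scatter) from compound 2 to compound 4, 1.7-fold (0.23 log units) apart, within the scatter of two such steps So both changes carry across within these four compounds, but this rests on just two pairs for each change, and on the core of compound 3 the chloro step alone cannot be told from scatter, so it shows no rule for other cores.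

The compounds shown leave open whether a bromo or methoxy group in place of the added chloro would follow the same course. They also leave open whether a trifluoromethyl group or an amine in place of the fluoro or methyl would behave as these two do.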